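This account rests on a few compounds, and the source may have more. Where it says the series, first, only, none or still open, it means among the compounds named here.

Within the data shown here, compound 2 `O=C(Nc1nn(-c2ccccc2)c(=O)c2ccccc12)c1ccco1` gives 8% in an assay on CHO cells for displacement of a labelled ligand from adenosine receptor A3 (Homo sapiens), tested at 1 uM (a higher number here means more inhibition at the concentration tested (going by the name of the read-out), a lower number less inhibition), the lowest of the two numbers measured so far; its nearest neighbour, compound 1 `O=C(Nc1ccccc1Cl)Nc1nn(-c2ccccc2)c(=O)c2ccccc12`, gives 49% in this assay. Compound 3 `Cc1ccccc1NC(=O)Nc1nn(-c2ccccc2)c(=O)c2ccccc12` differs from compound 2 by (2-methylphenyl)amino in place of furan-2-yl on a carbonyl carbon. Among the measured compounds shown here, the only step that bears on this is the one that went the other way: a number 41 percentage points lower from compound 1 to compound 2 (beyond the scatter). Since compound 3 restores an arylamino group on that carbonyl carbon, a step of comparable size, upward, is expected a number 37 percentage points higher from compound 2 to compound 3 (beyond the scatter). Compound 3 is therefore estimated at 45% in this assay, between 25% and 65%.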

Compound 3, a percentage reported as inhibition, at one concentration (the size of the read-out at that concentration, not a potency): 22%
Compound 3: the middle estimate sits 23 percentage points above what was measured; measured number outside the range, below it.
By their numbers in this assay, from the lowest: compound 2; then compound 3; then compound 1.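

In this assay, (2-methylphenyl)amino in place of furan-2-yl on the carbonyl carbon brings back only part of what was lost, with a number 14 percentage points higher from compound 2 to compound 3 (beyond the scatter) as the gain. The group on the aromatic carbon also counts, with a number 27 percentage points lower from compound 1 to compound 3 (beyond the scatter) on going to methyl in place of chloro, so an arylamino group alone does not restore the number of compound 1. Nothing shown here explains either step. Going by these compounds, it remains open whether bromo, fluoro or methoxy on that aromatic carbon would track chloro or methyl. On these data alone, it is equally open where plain phenylamino on the carbonyl carbon would fall.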